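The source may report more compounds than this note shows. Statements on the series, on what has been measured and on what is new or still open speak of the compounds shown alone.

Measured compounds:
Compound 1, `O=c1c2ccccc2[se]n1-c1nnc(-c2ccc(F)cc2)s1`, in a functional assay on MCF7 cells (Homo sapiens) for antiproliferative activity, read by CCK-8 assay, with a stated time of 48 h (on this read-out higher numbers stand for weaker inhibition and lower numbers for stronger inhibition), gives 61500 nM.
Compound 2, `O=c1c2ccccc2[se]n1-c1nnc(-c2ccccc2Br)s1`, in this assay gives 59400 nM.

Within the data shown here, compound 2 gives the lower of the two numbers in this assay, but its only neighbour, compound 1, sits so close that the two cannot be told apart. Among the measured compounds shown here, the step of a 1.0-fold lower number from compound 1 to compound 2 (0.02 log units; within the scatter) is the only measured step, and it shows that exchanging one substituted phenyl for another on this carbon of the shared core left the read-out where it was.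

Compound 3, `Cc1ccc(-c2nnc(-n3[se]c4ccccc4c3=O)s2)cc1`, is not yet measured. It differs from compound 2 by 4-methylphenyl in place of 2-bromophenyl on an aromatic carbon. For the measured compounds named here, the one step that bears on this change, a 1.0-fold lower number from compound 1 to compound 2 (0.02 log units; within the scatter), was flat, so for compound 3 no step beyond the scatter is expected in this assay, with an expected step of a 1.0-fold higher number from compound 2 to compound 3 (0.00 log units; within the scatter). Compound 3 is therefore estimated at 60000 nM, with a range from 30000 nM to 120000 nM.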

Compound 3, half-maximal inhibitory concentration: 18700 nM
Compound 3: the middle estimate sits 3.2-fold (0.51 log units) above what was measured; the measured number lies below the stated range.
By their numbers in this assay, from the lowest: compound 3; then compounds 2 and 1 (each within the scatter of the next).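

The flat first step had suggested that this carbon tolerates exchange of one substituted phenyl for another without consequence, but 4-methylphenyl in place of 2-bromophenyl gives a 3.2-fold lower number from compound 2 to compound 3 (0.50 log units; beyond the scatter) in this assay. The change of methyl in place of fluoro, which leaves the rest of the structure untouched, gives a 3.3-fold lower number from compound 1 to compound 3 (0.52 log units; beyond the scatter) and a step of modest size, so exchanging this one substituent on the phenyl ring is enough to move the read-out. Nothing available here explains why the methyl compound stands apart.

The compounds shown leave open whether an ethyl or a methoxy group in place of that methyl would lower the number further. They also leave open whether 2-methylphenyl or unsubstituted phenyl would match 4-methylphenyl.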